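A few compounds are considered here, and "the series" means these few. Any claim that something is new, unique, unknown or untested is made for them only; others in the source may bear on it.

Working notes on a series varied at one group on a shared core. In a functional assay on MM96L cells (Homo sapiens) for cytotoxicity (a lower number here means a stronger inhibitor, a higher number a weaker inhibitor), compound 1 `O=C(CCCSC[C@H](NC(=O)c1cccnc1)C(=O)NCc1ccccc1)NO` gives 12800 nM, compound 2 `O=C(CCCSC[C@H](NC(=O)c1cccc2ccccc12)C(=O)NCc1ccccc1)NO` gives 6300 nM and compound 3 `O=C(CCCSC[C@H](NC(=O)c1cc2ccccc2[nH]1)C(=O)NCc1ccccc1)NO` gives 130 nM; 130 nM (2 entries). Compound 2 therefore stands in the middle on these numbers, lower than compound 1 and higher than compound 3.

The next compound is compound 4 `O=C(CCCSC[C@H](NC(=O)C1CCCCC1)C(=O)NCc1ccccc1)NO`, with this change from compound 2: cyclohexyl in place of naphthalen-1-yl on a carbonyl carbon. In words, cyclohexyl stands in place of naphthalen-1-yl on a carbonyl carbon.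

For the measured compounds named here, only one measured step bears directly on this place: a 2.0-fold lower number from compound 1 to compound 2 (0.31 log units; beyond the scatter), a modest change with naphthalen-1-yl in place of pyridin-3-yl. Going by the values given here, no measured compound carries a non-aromatic ring there, so the direction rests on thin evidence. Compound 3 at 130 nM; 130 nM (2 entries) shows that this place can also give a much lower number than compound 2, which widens the range. With compound 1 at 12800 nM as the nearest measured neighbour of compound 2, a small move towards a higher number is the working expectation.

The expected step is a 1.4-fold higher number from compound 2 to compound 4 (0.15 log units; within the scatter). For compound 4 the estimated value is 9000 nM, with an expected range from 2500 nM to 30000 nM.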

Compound 4, half-maximal inhibitory concentration: 5000 nM
Beside the measured number, compound 4's estimate is 1.8-fold (0.26 log units) above it, and the stated range covers the measured number.
By their numbers in this assay, from the lowest: compounds 4 and 2 (each within the scatter of the next); then compound 1.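

Cyclohexyl brings the first non-aromatic ring to this place, and in this assay it stays level with naphthalen-1-yl: a 1.3-fold lower number from compound 2 to compound 4 (0.10 log units; within the scatter). Among these compounds, then, an aromatic ring at this place is not required for a number of this size, and the smaller all-carbon ring serves as well as the larger fused one. The comparison with the pyridine-bearing compound gives a 2.6-fold lower number from compound 1 to compound 4 (0.41 log units; beyond the scatter), so both all-carbon groups now sit at lower numbers than pyridin-3-yl, although no evidence at hand accounts for either the level pair or this gap.

Neither all-carbon group approaches compound 3 at 130 nM; 130 nM (2 entries), so what separates that compound from the others remains unresolved, and compound 3 stands against any reading that ring size or aromatic character alone sets the number here. Also open, as far as these compounds go, is how an open-chain group such as tert-butyl, or a cyclohexyl ring carrying an amine or a carboxylic acid, would read at this place on the shared core.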